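One Aryl Exchange Carried Over to a Second Core

The compounds below may be only part of what the source reports. "The series", "measured", "known", "first", "only" and "open" are said of these compounds alone.

Compound 1, `O=C(Nc1ccc(Oc2ccnc3[nH]ccc23)cc1)c1nn(-c2ccc(Br)cc2F)ccc1=O`, was tested in a functional assay on PC-3 cells (Homo sapiens) for cytotoxicity, read by MTT assay, with a stated time of 72 h (on this read-out lower numbers stand for stronger inhibition and higher numbers for weaker inhibition), and gave 12800 nM. Compound 2, `O=C(Nc1ccc(Oc2ccnc3[nH]ccc23)cc1)c1nn(-c2ccc(Cl)c(F)c2)ccc1=O`, differs from it in one place, (4-chloro-3-fluorophenyl in place of 4-bromo-2-fluorophenyl on an aromatic nitrogen), and in this assay compound 2 gave 7780 nM. That change made a 1.6-fold lower number from compound 1 to compound 2 (0.22 log units; within the scatter).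

Compound 3, `Cn1ccc2c(Oc3ccc(NC(=O)c4nn(-c5ccc(Br)cc5F)ccc4=O)cc3F)ccnc21`, carries a different core; how that core differs from the core of compound 1 is not broken down here. In this assay compound 3 gave 16300 nM. Against compound 1 this is the nearest value, and against compound 2 the gap is beyond the scatter.

Compound 4, `Cn1ccc2c(Oc3ccc(NC(=O)c4nn(-c5ccc(Cl)c(F)c5)ccc4=O)cc3F)ccnc21`, has not yet been measured. It stands to compound 3 as compound 2 stands to compound 1: 4-chloro-3-fluorophenyl in place of 4-bromo-2-fluorophenyl on an aromatic nitrogen. The place of the change is described in the same words for both pairs, so this is the same change made a second time, now on the core of compound 3.

Because a 1.6-fold lower number from compound 1 to compound 2 (0.22 log units; within the scatter) was the outcome of this change on the first core, compound 4 is expected to sit somewhat lower than compound 3, while the step is expected to stay within the scatter. The estimated step is a 1.6-fold lower number from compound 3 to compound 4 (0.21 log units; within the scatter). For compound 4 in this assay the estimate is 10000 nM, with an expected range from 5000 nM to 20000 nM.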

Compound 4, half-maximal inhibitory concentration: 17900 nM
Compound 4: the middle estimate sits 1.8-fold (0.25 log units) below what was measured, within the range that was stated.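

In this assay, putting 4-chloro-3-fluorophenyl in place of 4-bromo-2-fluorophenyl on the second core gave a 1.1-fold higher number from compound 3 to compound 4 (0.04 log units; within the scatter), so on this core, as on the first, the step is too small to be told apart from repeat-measurement noise. Set side by side, the two steps do not differ by more than repeated measurements of this kind allow: the same change on two cores in this assay, a 1.6-fold lower number (0.22 log units; within the scatter) from compound 1 to compound 2 and a 1.1-fold higher number (0.04 log units; within the scatter) from compound 3 to compound 4, 1.8-fold (0.26 log units) apart, within the scatter of two such steps. This shows that the change carried over to the second core without any step beyond the scatter, but it does not show that the change has a real effect of either sign, and two small steps do not establish that it would behave alike on any further core.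

All the compounds shown carry a halogen-bearing phenyl group on the aromatic nitrogen, which leaves open whether a phenyl group bearing an amine or a methoxy group in that place would move the number beyond the scatter in this assay. From the compounds shown here alone, all the values also come from this one assay on one cell line, so whether the same small steps would appear on other cells remains open.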